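Solubility of quinoline ether amides: a small-ring amide variant

A few compounds are considered here, and "the series" means these few. Any claim that something is new, unique, unknown or untested is made for them only; others in the source may bear on it.

Measured compounds and their values in a physicochemical assay for solubility, in phosphate buffer, measured as kinetic solubility, with a stated time of 1 h, at pH 7.4; on this read-out higher numbers stand for higher solubility and lower numbers for lower solubility:
Compound 1, `COc1ccc2nc(C)cc(OCC(=O)Nc3cccc(C)c3)c2c1`: 193000 nM
Compound 2, `COc1ccc2nc(C)cc(OCC(=O)Nc3ccc(Br)c(C)c3)c2c1`: its value is a limit of the assay, < 1000 nM
Compound 3, `COc1ccc2nc(C)cc(OCC(=O)Nc3c(C)cncc3C)c2c1`: 12000 nM

Among the numbers shown, compound 3 gives the lowest one, with compound 1 its nearest neighbour, a 16-fold lower number from compound 1 to compound 3 (1.21 log units; beyond the scatter). Compound 2 sits at a limit of this assay, (the limit of < 1000 nM in this assay, at which 1 of the 3 values shown sits), so its value is a limit and not a number; from compound 2 to compound 3 the step was an at least 12-fold higher number from compound 2 to compound 3 (1.07 log units; beyond the scatter), and from compound 1 to compound 2 it was an at least 190-fold lower number from compound 1 to compound 2 (2.28 log units; beyond the scatter).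

Compound 4, `COc1ccc2nc(C)cc(OCC(=O)NC3CONC3=O)c2c1`, has not yet been measured. It differs from compound 3 in this way: a group of 6 heavy atoms (3 carbon, 1 nitrogen, 2 oxygen; one five-membered non-aromatic ring with 2 hetero atoms) in place of a group of 8 heavy atoms (7 carbon, 1 nitrogen; one six-membered aromatic ring with 1 hetero atom), on an amide-type nitrogen. All three measured steps alter the group on the amide-type nitrogen, and each was large, so the number is expected to move well beyond the scatter here too. None of them exchanges an aromatic ring for a five-membered non-aromatic ring with 2 hetero atoms and 1 hydrogen-bond donor, so direction rests on analogy alone. Compound 4 is expected to give 60000 nM (range 15000 nM to 250000 nM), a step estimated as a 5.0-fold higher number from compound 3 to compound 4 (0.70 log units; beyond the scatter).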

Compound 4, solubility: >= 166000 nM
Compound 4 ended at the assay's limit; the forecaster's own chance of this, stated with the estimate: 5%; middle value at least 2.7-fold (0.44 log units) from the limit.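

Putting this five-membered non-aromatic ring with 2 hetero atoms on the amide-type nitrogen, in place of 3,5-dimethylpyridin-4-yl, gave an at least 13-fold higher number from compound 3 to compound 4 (1.14 log units; beyond the scatter) in this assay. This shows that the position tolerates a group with no aromatic ring, whereas every earlier compound carried a six-membered aromatic ring there, and the same exchange starting from 4-bromo-3-methylphenyl gave an at least 160-fold higher number from compound 2 to compound 4 (2.22 log units; beyond the scatter). Compound 4 sits at a limit of the assay rather than at a number, so its true height is unknown and the step from compound 1 cannot be read: the limit of >= 166000 nM in this assay, at which 1 of the 4 values shown sits.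

The compounds shown leave open whether the step belongs to the loss of the aromatic ring or to the hydrogen-bond donor and the hetero atoms that enter with the new ring, as these all change together from compound 3 to compound 4. A plain cyclopentyl group or a morpholine on the amide-type nitrogen would bear on that question, and whether compound 4 stands apart from compound 1 also remains unsettled.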